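A few compounds are considered here, and "the series" means these few. Any claim that something is new, unique, unknown or untested is made for them only; others in the source may bear on it.

Measured compounds:
compound 1 `C=C1[C@@H](O)[C@H](n2cnc3c(S)nc(N)nc32)O[C@@H]1CO` — 207000 nM
compound 2 `C=C1[C@@H](O)[C@H](n2cnc3c(SC)nc(N)nc32)O[C@@H]1CO` — a limit, > 500000 nM
compound 3 `C=C1[C@H](n2cnc3c(S)nc(N)nc32)O[C@H](CO)[C@H]1O` — 20000 nM

Of the compounds shown here, three have been measured in a functional assay on L1210 cells (Mus musculus) for inhibition; a lower number here means a stronger inhibitor, a higher number a weaker inhibitor. In this assay compound 1 gives 207000 nM. For compound 2 only a limit is reported, > 500000 nM, which is the edge of this assay and not a number. Compound 3 gives 20000 nM in this assay, the lowest number of the two numbers recorded; compound 1 stands nearest to it with a higher number. Compound 3 and compound 1 share the same atoms joined differently; the difference between the two cores is not broken down here.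

Among the compounds with values here, the one change that can be read from the measured pairs is methyl in place of hydrogen on a sulfur. It produced an at least 2.4-fold higher number from compound 1 to compound 2 (0.38 log units; beyond the scatter). The size of that step is only a lower bound, because the value of compound 2 sits at the limit of > 500000 nM in this assay, at which 1 of the 3 values shown sits.

Compound 4 `C=C1[C@H](n2cnc3c(SC)nc(N)nc32)O[C@H](CO)[C@H]1O` is not yet measured. It stands to compound 3 as compound 2 stands to compound 1: the change is methyl in place of hydrogen on a sulfur, the same change at the same place, since both sulfur atoms carry an aromatic carbon as their other neighbour. Compound 4 is therefore expected to be a weaker inhibitor than compound 3, with a step estimated at a 7.5-fold higher number from compound 3 to compound 4 (0.88 log units; beyond the scatter), resting on an at least 2.4-fold higher number from compound 1 to compound 2 (0.38 log units; beyond the scatter) observed for the same change. The expected value of compound 4 in this assay is 150000 nM, within an estimated range from 40000 nM to 500000 nM.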

Compound 4, half-maximal inhibitory concentration: > 500000 nM
Compound 4: only a limit was reported; the forecaster's own chance of this, stated with the estimate: 20%; middle value at least 3.3-fold (0.52 log units) away from the limit.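

In this assay, methyl in place of hydrogen on a sulfur again gave a weaker inhibitor when carried onto the core of compound 3, with an at least 25-fold higher number from compound 3 to compound 4 (1.39 log units; beyond the scatter). The direction of the change therefore held on both cores in this small set, and neither of the two pairs goes against it, but both methylsulfanyl compounds end at a limit of the assay and not at a number: the limit of > 500000 nM in this assay, at which 2 of the 4 values shown sit. Both steps are thus lower bounds and give no true size, so these data do not show whether the change costs more on one core than on the other: the same change on two cores in this assay, an at least 2.4-fold higher number (0.38 log units; beyond the scatter) from compound 1 to compound 2 and an at least 25-fold higher number (1.39 log units; beyond the scatter) from compound 3 to compound 4; the limit leaves it open whether they differ.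

The compounds shown leave open whether any other group on this sulfur would retain inhibition on either core, for instance an ethyl group, a longer chain or a benzyl group, since methyl is the only one shown here. They also leave open how an amine or a hydroxyl group in place of the sulfanyl group would compare, and whether the gap between compound 1 and compound 3 would persist with such groups.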